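Amine swap on a shared core toward compound 3

A few compounds are considered here, and "the series" means these few. Any claim that something is new, unique, unknown or untested is made for them only; others in the source may bear on it.

Two measured members share one core, seen in compound 1 `CCC(CC)Nc1nc(C)nc2c(-c3cc(F)c(OC)cc3C)c(C)nn12` and compound 2 `C=CCN(CC=C)c1nc(C)nc2c(-c3c(C)cc(OC)cc3OC)c(C)nn12`. In an assay on cell membranes for displacement of a labelled ligand from corticotropin-releasing factor receptor 1 (Rattus norvegicus) (on this read-out lower numbers stand for stronger inhibition and higher numbers for weaker inhibition), compound 1 gives 1.9 nM, and in the same read-out compound 2 gives 1 nM. Compound 2 holds the lowest of the two numbers, but its nearest neighbour is compound 1 and the gap between them lies within the scatter, so no order can be stated between them.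

Compound 3 `CCC(CC)Nc1nc(C)nc2c(-c3c(C)cc(OC)cc3OC)c(C)nn12` joins the aryl group of compound 2 with the amine of compound 1. Computed from the two structures, the change from compound 2 is (pentan-3-yl)amino in place of diallylamino on an aromatic carbon. Among the compounds with values here, no step between measured compounds isolates this single change, so its effect must be judged from the two numbers at hand. Since compound 1 carrying (pentan-3-yl)amino gives 1.9 nM while compound 2 carrying diallylamino gives 1 nM, both amines sit in compounds with closely matched numbers.

Compound 3 is therefore expected to give 1.5 nM in this assay, within 0.6 nM to 4 nM. The expected step, a 1.5-fold higher number from compound 2 to compound 3 (0.18 log units; within the scatter), should stay within the scatter, with no direction beyond it.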

Compound 3, half-maximal inhibitory concentration: 5 nM
Beside the measured number, compound 3's estimate is 3.3-fold (0.52 log units) below it; the whole stated range lies below it.
By their numbers in this assay, from the lowest: compounds 2 and 1 (each within the scatter of the next); then compound 3.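

With the aryl group of compound 2 held fixed, placing (pentan-3-yl)amino in place of diallylamino on this aromatic carbon, between two ring nitrogen atoms, gives in this assay a 5.0-fold higher number from compound 2 to compound 3 (0.70 log units; beyond the scatter), a modest step but one beyond the scatter. Within the data shown here, this is the first single-place comparison at this position, and it shows that the position is not indifferent to the choice of amine. Compounds 1 and 2 could not show this, as they differ in more than one place and their numbers lie within the scatter of each other.

The change removes both allyl double bonds and brings in a hydrogen-bond donor that diallylamino lacks, and it also alters the chain shape, so this single step leaves open which of these features goes with the higher number; dipropylamino, which keeps the amine fully substituted without double bonds, or a cyclopropylmethylamino group on the same carbon would pull these features apart. Nothing at hand gives a cause for the step.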